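Cleaving the Ester of Compound 3: Expected Cytotoxicity Shift

This account rests on a few compounds, and the source may have more. Where it says the series, first, only, none or still open, it means among the compounds named here.

Compound 1 `CC(C)(C)C(=O)OC1CC2(N3CCCCC3)CC(c3ccccc3)C1C(c1ccccc1)C2`: 12000 nM
Compound 2 `OC1CC2(N3CCCCC3)CC(c3ccccc3)C1C(c1ccccc1)C2`: 37300 nM
Compound 3 `O=C(CN1CCCCC1)OC1CC2(N3CCCC3)CC(c3ccccc3)C1C(c1ccccc1)C2`: 14200 nM

All three compounds share one core and were tested in an ADME assay on L6 cells (Rattus norvegicus) for cytotoxicity, with a stated time of 72 h; a lower number here means a stronger inhibitor, a higher number a weaker inhibitor. Compound 3 gives the second highest of the three numbers; its nearest neighbour is compound 1, whose value lies within the scatter of it, while compound 2 stands beyond the scatter above it. Compound 4 `OC1CC2(N3CCCC3)CC(c3ccccc3)C1C(c1ccccc1)C2` has not yet been measured; it differs from compound 3 by hydrogen in place of ((piperidin-1-yl)methyl)carbonyl on an oxygen on a saturated carbon. For the measured compounds named here, one measured step bears on this change: the step of a 3.1-fold higher number from compound 1 to compound 2 (0.49 log units; beyond the scatter), which is also an ester to alcohol change on the same oxygen. A step of similar size and direction is therefore expected for compound 4 in this assay, namely a 2.5-fold higher number from compound 3 to compound 4 (0.39 log units; beyond the scatter). Compound 4 is thus estimated at 35000 nM, with a range from 15000 nM to 90000 nM.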

Compound 4, half-maximal inhibitory concentration: 26800 nM
For compound 4 the middle estimate is 1.3-fold (0.12 log units) above the measured one, within the range that was stated.
By their numbers in this assay, from the lowest: compounds 1, 3, 4 and 2 (each within the scatter of the next, the first and the last beyond it).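

Removing the ((piperidin-1-yl)methyl)carbonyl from this oxygen gives a 1.9-fold higher number from compound 3 to compound 4 (0.28 log units; within the scatter) in this assay and so stays within the scatter, whereas removing the (tert-butyl)carbonyl gave a 3.1-fold higher number from compound 1 to compound 2 (0.49 log units; beyond the scatter) and went beyond it. At this position, then, the two esters do not show the same clear separation from their alcohols. With the free hydroxy group in place, the exchange on the saturated ring carbon gives a 1.4-fold lower number from compound 2 to compound 4 (0.14 log units; within the scatter) and also stays within the scatter.

Going by these compounds, what a methyl ether or an acetyl ester on this oxygen would give remains open. No supporting evidence bears on these steps.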